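The compounds below may be only part of what the source reports. "The series", "measured", "known", "first", "only" and "open" are said of these compounds alone.

Measured in a physicochemical assay for lipophilicity; on this read-out lower numbers stand for lower lipophilicity and higher numbers for higher lipophilicity:
compound 1 `CS(=O)(=O)c1ccc2sc(NC(=O)NC(=O)c3ccccc3Cl)nc2c1`: 2.8
compound 2 `CN1CCC(S(=O)(=O)c2ccc3nc(NC(=O)NC(=O)c4cc5c(cc4Cl)CCN5C)sc3c2)CC1`: 2.8
compound 3 `Cc1cc(C)n(-c2ccc(Cl)c(C(=O)NC(=O)Nc3nc4ccc(S(=O)(=O)CCCN5CCN(C)CC5)cc4s3)c2)n1`: 2.5

Compound 3 at 2.5 lies within the scatter of both compound 1 and compound 2, so these values give no order. Compound 4 `CCOc1ccc(Cl)c(C(=O)NC(=O)Nc2nc3ccc(S(=O)(=O)CCCN4CCN(C)CC4)cc3s2)c1`, still unmeasured, differs from compound 3 in one place: ethoxy in place of 3,5-dimethyl-1H-pyrazol-1-yl on an aromatic carbon, with ethoxy in place of 3,5-dimethyl-1H-pyrazol-1-yl on an aromatic carbon. Among the measured compounds shown here, no measured pair isolates this kind of change, so the expectation rests only on the close values of three different structures. The expected a number 0.20 log units lower from compound 3 to compound 4 (within the scatter) in this assay is small and downward, not beyond the scatter. The estimate for compound 4 is 2.3, with an expected range of 1.9 to 2.7.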

Compound 4, distribution coefficient: 2.4
The estimate for compound 4 lay 0.10 log units below the measured number, and the stated range covers the measured number.
By their numbers in this assay, from the lowest: compounds 4, 3, 1 and 2 (each within the scatter of the next, the first and the last beyond it).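

Ethoxy in place of 3,5-dimethyl-1H-pyrazol-1-yl gives the first single-place comparison in the series: in this assay it yields a number 0.10 log units lower from compound 3 to compound 4 (within the scatter). At this aromatic carbon, para to a chloro group, replacing the five-membered aromatic ring with an open ethoxy group and fewer heavy atoms therefore leaves no resolved difference. Nothing at hand gives a reason for this result.

From the compounds shown here alone, whether an amine or a carboxylic acid at this position would move the number beyond the scatter remains open. So does whether a longer chain in place of ethoxy would do so.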